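The compounds below may be only part of what the source reports. "The series", "measured", "known", "first", "only" and "open" are said of these compounds alone.

- compound 1 `COc1cc(Cl)ccc1C(=O)Nc1cc(Cl)ccc1O`: 87000 nM
- compound 2 `COc1cc(Cl)ccc1C(=O)Nc1cc(Cl)c(Cl)cc1O`: 11500 nM
- compound 3 `COc1cc(Cl)ccc1C(=O)Nc1cc(Br)ccc1O`: not yet measured

Among the compounds with values here, in a functional assay on HepG2 cells (Homo sapiens) for cytotoxicity, with a stated time of 24 h (on this read-out higher numbers stand for weaker inhibition and lower numbers for stronger inhibition), compound 1 gives 87000 nM, the higher of the two numbers so far. Compound 3 differs from it as follows: bromo in place of chloro on an aromatic carbon. This is bromo in place of chloro on an aromatic carbon, para to a hydroxy group. No exchange of this kind has been measured in the series. The nearest evidence is a 7.6-fold lower number from compound 1 to compound 2 (0.88 log units; beyond the scatter), a modest step beyond the scatter, made by chloro in place of hydrogen on an aromatic carbon. Compound 2, at 11500 nM, is therefore only a loose guide, and it points weakly towards a lower number. The expected change is small, within the scatter, and is estimated as a 1.5-fold lower number from compound 1 to compound 3 (0.16 log units; within the scatter). The estimate for compound 3 is 60000 nM, with an expected range of 25000 nM to 130000 nM.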

Compound 3, half-maximal inhibitory concentration: 5630 nM
Compound 3: the middle estimate sits 11-fold (1.03 log units) above what was measured; measured number outside the range, below it.
By their numbers in this assay, from the lowest: compound 3; then compound 2; then compound 1.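

In this assay the aromatic carbon para to a hydroxy group proves sensitive to which halogen it carries: the exchange of chloro for bromo gives a 15-fold lower number from compound 1 to compound 3 (1.19 log units; beyond the scatter) as a large step, although no ring, hydrogen-bond donor, hydrogen-bond acceptor or net charge changes. The earlier pair showed only a 7.6-fold lower number from compound 1 to compound 2 (0.88 log units; beyond the scatter) on adding a chloro in place of hydrogen elsewhere on the aromatic ring, and it said nothing about replacing the halogen at this position. Nothing at hand accounts for the size of the bromo step.

On these data alone, whether iodo, methyl or trifluoromethyl at this position would extend the step remains open. Also open, as far as these compounds go, is whether bromo here would combine with the added chloro of compound 2, and whether the step depends on the hydroxy group.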